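The source may hold more compounds than are shown below. What is called first, only, known or untested is meant among the compounds shown, and "the series" means these compounds.

Compound 1, `c1ccc(-c2ccncn2)c(OCC2=NCCN2)c1`, in a functional assay for activation of Alpha-1A adrenergic receptor (Homo sapiens), read by calcium flux (on this read-out higher numbers stand for an effect only at larger amounts of compound and lower numbers for an effect already at smaller amounts), gives < 100000 nM, which is a limit of the assay and not a number.
Compound 2, `c1ccc(-c2ccsc2)c(OCC2=NCCN2)c1`, in this assay gives 0.251 nM.
Compound 3, `Cc1ccoc1-c1ccccc1OCC1=NCCN1`, in this assay gives 3.16 nM.

Among the two real numbers, compound 3 has the higher one; its nearest neighbour is compound 2, and the step runs as a 13-fold higher number from compound 2 to compound 3 (1.10 log units; beyond the scatter). The steps from compound 1 are another matter: a step that the limit leaves unreadable from compound 1 to compound 2 and a step that the limit leaves unreadable from compound 1 to compound 3 cannot be sized, because compound 1 sits at the limit of < 100000 nM in this assay, at which 1 of the 3 values shown sits.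

Compound 4, `Cc1csc(-c2ccccc2OCC2=NCCN2)n1`, has not yet been measured. It differs from compound 3 in one place: 4-methyl-1,3-thiazol-2-yl in place of 3-methylfuran-2-yl on an aromatic carbon. Within the data shown here, the only step that can be read, from compound 2 to compound 3, shows that swapping one five-membered ring for another on this carbon of the shared core can move the number a good deal. The entering ring carries two hetero atoms, as did the ring of compound 1, whose result could not be read. Taking the readable step as the scale of what such a swap does, the expected outcome is a moderately higher number, roughly a 3.2-fold higher number from compound 3 to compound 4 (0.50 log units; beyond the scatter).

For compound 4 the estimate in this assay is therefore 10 nM, with a likely range from 1 nM to 100 nM.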

Compound 4, half-maximal effective concentration: 25.1 nM
Estimate against measurement, compound 4: 2.5-fold (0.40 log units) below; the measured number falls inside the stated range.
By their numbers in this assay, from the lowest: compound 2; then compound 3; then compound 4.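

In this assay, the 4-methyl-1,3-thiazol-2-yl ring still gives a real number, so on this aromatic carbon a ring with two hetero atoms can be read, which the ring of compound 1 did not allow. The change also shows that two five-membered aromatic rings with the same count of heavy atoms need not behave alike: exchanging 3-methylfuran-2-yl for 4-methyl-1,3-thiazol-2-yl gives a 7.9-fold higher number from compound 3 to compound 4 (0.90 log units; beyond the scatter), and measured against thiophen-3-yl the same ring gives a 100-fold higher number from compound 2 to compound 4 (2.00 log units; beyond the scatter), which makes compound 4 the highest of the three real numbers. The steps from compound 1 to the other compounds cannot be read, because the result for compound 1 is a limit and not a number: the limit of < 100000 nM in this assay, at which 1 of the 4 values shown sits.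

Plain 1,3-thiazol-2-yl, without its methyl group, is not among the compounds shown, so the parts played by the methyl group and by the ring itself in these steps remain unseparated. Also open, from the compounds shown here alone, is how a group that is not a ring, such as an amine or a short alkyl chain, would compare on this carbon.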